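Shifting the nitro group on the thiourea aryl ring

This account rests on a few compounds, and the source may have more. Where it says the series, first, only, none or still open, it means among the compounds named here.

Three thioureas share one core and have been tested in a functional assay on the whole organism (strain Swiss albino) with Mus musculus as the target, in the maximal electroshock model, with a stated time of 0.5 h; on this read-out lower numbers stand for an effect already at smaller amounts and higher numbers for an effect only at larger amounts of compound. Compound 1 `COc1cc2c(cc1OC)C(=O)C(CC1CCN(C(=S)Nc3ccccc3)CC1)C2` gives 100 mg/kg; compound 2 `COc1cc2c(cc1OC)C(=O)C(CC1CCN(C(=S)Nc3cccc(C)c3)CC1)C2` gives 300 mg/kg; compound 3 `COc1cc2c(cc1OC)C(=O)C(CC1CCN(C(=S)Nc3cccc([N+](=O)[O-])c3)CC1)C2` gives 300 mg/kg. Compound 3 thus stands level with compound 2 at the digits reported, the two together at the high end of the three numbers, while compound 1 sits lower, with a 3.0-fold higher number from compound 1 to compound 3 (0.48 log units; beyond the scatter) and a 3.0-fold higher number from compound 1 to compound 2 (0.48 log units; beyond the scatter); between the two substituted analogues there is no change at the digits printed from compound 2 to compound 3 (within the scatter).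

Compound 4 `COc1cc2c(cc1OC)C(=O)C(CC1CCN(C(=S)Nc3ccc([N+](=O)[O-])cc3)CC1)C2` keeps every atom of compound 3 but joins them differently: 4-nitrophenyl in place of 3-nitrophenyl on an amide-type nitrogen. For the measured compounds named here, no measured pair moves a substituent from one ring position to another, so no step bears directly on this change; the only guidance is that the two substituted rings, whatever the group, gave numbers within the scatter of each other. Compound 4 is therefore expected to show no change at the digits printed from compound 3 to compound 4 (within the scatter), and its value in this assay is estimated at 300 mg/kg, within 100 mg/kg to 600 mg/kg.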

Compound 4, minimum effective dose: 30 mg/kg
Compound 4: the middle estimate sits 10-fold (1.00 log units) above what was measured; the measured number lies below the stated range.
By their numbers in this assay, from the lowest: compound 4; then compound 1; then compounds 2 and 3 (each within the scatter of the next).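

In this assay the place of the nitro group on the ring proves to matter: with no atom gained or lost, 4-nitrophenyl in place of 3-nitrophenyl gives a 10-fold lower number from compound 3 to compound 4 (1.00 log units; beyond the scatter) on this amide-type nitrogen, and 4-nitrophenyl in place of 3-methylphenyl gives a 10-fold lower number from compound 2 to compound 4 (1.00 log units; beyond the scatter) in the same read-out. Substitution on this ring can no longer be read as a loss in general, since nitro in place of hydrogen now gives a 3.3-fold lower number from compound 1 to compound 4 (0.52 log units; beyond the scatter) and so runs opposite to the step seen with the 3-nitrophenyl ring of compound 3. Nothing available explains the gap between the two nitrophenyl rings.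

The compounds shown leave open whether the low number of compound 4 belongs to the nitro group itself or to the place it holds. A nitrile or a methyl group in that same place on the ring would separate the two.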